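Methyl on the oxygen-bearing ring carbon across two end groups

A few compounds are considered here, and "the series" means these few. Any claim that something is new, unique, unknown or untested is made for them only; others in the source may bear on it.

Compound 1 `O=C1NC(=O)/C(=C/C2=Cc3cc(Br)ccc3OC2)S1` is the parent of the series; in a functional assay on MCF7 cells (Homo sapiens) for antiproliferative activity, read by MTT assay, with a stated time of 72 h (on this read-out higher numbers stand for weaker inhibition and lower numbers for stronger inhibition), compound 1 gives 57900 nM. Compound 2 `O=C1NC(=S)S/C1=C\C1=Cc2cc(Br)ccc2OC1` shares the brominated bicyclic part but differs in the five-membered end group; how the two cores differ is not broken down here. In this assay compound 2 gives 40400 nM, a number within the scatter of compound 1. Compound 3 `CC1Oc2ccc(Br)cc2C=C1/C=C1\SC(=O)NC1=O` is compound 1 with the change (methyl in place of hydrogen on a saturated ring carbon); in this assay compound 3 gives 67600 nM, and the step of a 1.2-fold higher number from compound 1 to compound 3 (0.07 log units; within the scatter) is within the scatter, so this pair shows no movement that can be trusted.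

Compound 4 `CC1Oc2ccc(Br)cc2C=C1/C=C1\SC(=S)NC1=O` has not yet been measured. It stands to compound 2 as compound 3 stands to compound 1: the change methyl in place of hydrogen on a saturated ring carbon is the same change, at the same place. Going by the values given here, the expectation rests on the single measured instance of this change, a 1.2-fold higher number from compound 1 to compound 3 (0.07 log units; within the scatter), which stayed within the scatter; the step from compound 2 to compound 4 is therefore expected to be of like size, a 1.2-fold higher number from compound 2 to compound 4 (0.07 log units; within the scatter). For compound 4 the estimated value in this assay is 47000 nM, expected to fall between 24000 nM and 95000 nM.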

Compound 4, half-maximal inhibitory concentration: 19900 nM
The estimate for compound 4 lay 2.4-fold (0.37 log units) above the measured number; measured number below the stated range.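

On the core of compound 2, methyl in place of hydrogen on a saturated ring carbon gives in this assay a 2.0-fold lower number from compound 2 to compound 4 (0.31 log units; beyond the scatter), a modest step. Set beside the same change on the core of compound 1, this step gives no ground for saying that the change acts differently on the two cores: the same change on two cores in this assay, a 1.2-fold higher number (0.07 log units; within the scatter) from compound 1 to compound 3 and a 2.0-fold lower number (0.31 log units; beyond the scatter) from compound 2 to compound 4, 2.4-fold (0.37 log units) apart, within the scatter of two such steps. The pair of steps fits a carry-over from one core to the other but does not prove one, and no general lowering of the number by methyl can be claimed, as the step to compound 3 goes against it by staying within the scatter.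

The compounds shown leave open how the number would respond to an ethyl group, a longer chain or a carboxylic acid on the same saturated ring carbon. Going by these compounds alone, with only two pairs, both read in a single assay, it also remains open whether the modest step to compound 4 would hold on any further core.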